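The compounds below may be only part of what the source reports. "The series", "measured", "known", "first", "only" and "open" are said of these compounds alone.

Compound 3 `O=C(Nc1cccnc1)c1ccccc1OCc1cccc(Cl)c1F` sits in the middle of a short series of three analogues that share one core and differ only in the aryl group on a saturated chain carbon bound to an oxygen on an aromatic ring. In an assay on lysate for inhibition of phosphatidylcholine:ceramide cholinephosphotransferase 2 (Homo sapiens), read by HPLC, with stated times of 30 min and 2 h (a lower number here means a stronger inhibitor, a higher number a weaker inhibitor), compound 3 gives 3100 nM. Compound 1 `O=C(Nc1cccnc1)c1ccccc1OCc1ccccc1` carries a plain phenyl there and gives 3200 nM in this assay, so that a 1.0-fold lower number from compound 1 to compound 3 (0.01 log units; within the scatter). Compound 2 `O=C(Nc1cccnc1)c1ccccc1OCc1cc(F)ccc1Cl` carries a 2-chloro-5-fluorophenyl and gives 740 nM in this assay, and a 4.3-fold lower number from compound 1 to compound 2 (0.64 log units; beyond the scatter), while a 4.2-fold higher number from compound 2 to compound 3 (0.62 log units; beyond the scatter). Compound 3 therefore stands with the weaker pair of the three, a gap beyond the scatter separating it from compound 2.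

Compound 4 `Cc1ccc(F)cc1COc1ccccc1C(=O)Nc1cccnc1` is reached by 5-fluoro-2-methylphenyl in place of 3-chloro-2-fluorophenyl on a saturated chain carbon bound to an oxygen on an aromatic ring. Its 5-fluoro-2-methylphenyl is named like the 2-chloro-5-fluorophenyl of compound 2, which gave the only modest gain seen so far, so a step of similar direction is expected, and the estimated change is a 2.8-fold lower number from compound 3 to compound 4 (0.45 log units; beyond the scatter). Compound 4 is accordingly expected to give about 1100 nM in this assay, most likely between 400 nM and 3200 nM.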

Compound 4, half-maximal inhibitory concentration: 740 nM
The estimate for compound 4 lay 1.5-fold (0.17 log units) above the measured number; the measured number falls inside the stated range.
By their numbers in this assay, from the lowest: compounds 2 and 4 (each within the scatter of the next); then compounds 3 and 1 (each within the scatter of the next).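

In this assay the exchange of chloro for methyl on an aromatic carbon gives no change at the digits printed from compound 2 to compound 4 (within the scatter), so the gain over plain phenyl seen with compound 2 does not depend on the chloro, and methyl serves equally well in this aryl group. The 5-fluoro-2-methylphenyl group gives a 4.3-fold lower number from compound 1 to compound 4 (0.64 log units; beyond the scatter) and also a 4.2-fold lower number from compound 3 to compound 4 (0.62 log units; beyond the scatter); compound 3, which carries chlorine and fluorine too, goes against any reading that halogens on this ring are enough for a gain. No measurement at hand explains why these two groups match.

The compounds shown leave open what the fluoro contributes on its own in these two aryl groups. They also leave open whether a methoxy, an ethyl or a trifluoromethyl in place of the methyl would hold the same number.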